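Replacing chloro with cyclopropyl in compound 2

The compounds below may be only part of what the source reports. "The series", "measured", "known", "first", "only" and "open" are said of these compounds alone.

Of the compounds shown here, two have been measured so far in a physicochemical assay for lipophilicity, read by HPLC, at pH 7.5; a higher number here means a more lipophilic compound, a lower number a more polar compound. Compound 1 (`Cc1c(-c2ccccc2)nc2ccc(I)cc2c1C(=O)Nc1ccc(C(=O)O)cc1F`) gives 2, and compound 2 (`O=C(O)c1ccc(NC(=O)c2c(Cl)c(-c3ccccc3)nc3ccc(Br)cc23)c(F)c1`) gives 2.1. These two numbers lie within the usual scatter of repeated measurements, so compound 2 stands level with compound 1 on present data.

Compound 3 (`O=C(O)c1ccc(NC(=O)c2c(C3CC3)c(-c3ccccc3)nc3ccc(Br)cc23)c(F)c1`) has cyclopropyl in place of chloro on an aromatic carbon. The swap sits ortho to a phenyl group and two atoms from the ring nitrogen.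

Among the compounds with values here, no measured pair differs in one place only, so nothing here shows directly what a single swap does in this assay. The expected change is a small rise, a number 0.30 log units higher from compound 2 to compound 3 (within the scatter), close to the edge of the scatter. For compound 3 the estimated value is 2.4, with an expected range from 2 to 2.9.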

Compound 3, distribution coefficient: 2.1
Compound 3: middle estimate off by 0.30 log units, on the high side, and the stated range covers the measured number.
By their numbers in this assay, from the lowest: compounds 1, 2 and 3 (each within the scatter of the next).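

In this assay, within the data shown here, cyclopropyl in place of chloro on this aromatic carbon gives no change at the digits printed from compound 2 to compound 3 (within the scatter) and provides the first comparison here of compounds that differ in one place only. At this position, ortho to a phenyl group and two atoms from the ring nitrogen, going from 1 heavy atom to 3 heavy atoms and adding a three-membered ring therefore leaves the reading level within the scatter. No supporting measurement is available to explain this result.

Among these compounds, this single step covers only one swap at one position, so it sets no general rule for other groups or places. From the compounds shown here alone, whether an amine or a longer chain on this same aromatic carbon would also leave the reading level remains open.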